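Replacing 4-methylbenzyl with 3,4-difluorobenzyl in a cytotoxic series

The source may report more compounds than this note shows. Statements on the series, on what has been measured and on what is new or still open speak of the compounds shown alone.

In a functional assay on MDA-MB-231 cells (Homo sapiens) for cytotoxicity, read by MTT assay, with a stated time of 48 h (a higher number here means a weaker inhibitor, a lower number a stronger inhibitor), compound 1 `O=C(O)CN1C(=O)/C(=C/c2nc3ccccc3n2Cc2ccc(Br)cc2F)SC1=S` gives 28400 nM, compound 2 `O=C(O)CN1C(=O)/C(=C/c2nc3ccccc3n2Cc2ccc([N+](=O)[O-])cc2)SC1=S` gives 7760 nM, and compound 3 `Cc1ccc(Cn2c(/C=C3\SC(=S)N(CC(=O)O)C3=O)nc3ccccc32)cc1` gives 1040 nM. Compound 3 therefore has the lowest number of the three and is the strongest inhibitor measured so far. The change under consideration leads to compound 4 `O=C(O)CN1C(=O)/C(=C/c2nc3ccccc3n2Cc2ccc(F)c(F)c2)SC1=S`, with 3,4-difluorophenyl in place of 4-methylphenyl on a saturated chain carbon bound to an aromatic nitrogen. Two measured steps at this place end in the 4-methylphenyl group. The large one, starting from 4-bromo-2-fluorophenyl, is a 27-fold lower number from compound 1 to compound 3 (1.44 log units; beyond the scatter). The modest one, starting from 4-nitrophenyl, is a 7.5-fold lower number from compound 2 to compound 3 (0.87 log units; beyond the scatter). Neither compound 1 nor compound 2 carries the incoming group, so the guidance is loose. Still, both steps suggest that leaving 4-methylphenyl will raise the number, and a modest step upward is expected in this assay. For compound 4 the estimated value is 5500 nM, with an expected range from 1500 nM to 18000 nM. This estimate means a 5.3-fold higher number from compound 3 to compound 4 (0.72 log units; beyond the scatter).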

Compound 4, half-maximal inhibitory concentration: 3760 nM
Beside the measured number, compound 4's estimate is 1.5-fold (0.17 log units) above it; the measured number falls inside the stated range.
By their numbers in this assay, from the lowest: compound 3; then compound 4; then compound 2; then compound 1.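

In this assay, a third group now sits above 4-methylphenyl at this place, with a 3.6-fold higher number from compound 3 to compound 4 (0.56 log units; beyond the scatter), so compound 3 stays the strongest inhibitor of the four. The two groups that carry fluorine lie far apart, with a 7.6-fold lower number from compound 1 to compound 4 (0.88 log units; beyond the scatter), which shows that fluorine on the ring does not by itself bring the high number of compound 1. The 3,4-difluorophenyl group also gives a lower number than 4-nitrophenyl, with a 2.1-fold lower number from compound 2 to compound 4 (0.31 log units; beyond the scatter), and so takes second place in the series.

No measurement shown bears on why the groups fall in this order. The compounds shown leave open how an unsubstituted phenyl or a cyclohexyl group would fare on the same chain carbon, and whether a methyl ester could stand in for the carboxylic acid.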